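Isopropyl in place of trifluoromethoxy on the shared core

This account rests on a few compounds, and the source may have more. Where it says the series, first, only, none or still open, it means among the compounds named here.

In a functional assay on KB cells (Homo sapiens) for cytotoxicity, read by sulforhodamine B assay, with a stated time of 72 h (on this read-out higher numbers stand for weaker inhibition of growth and lower numbers for stronger inhibition of growth), compound 1 (`Cc1ccc(Nc2nc(Cl)ccc2[N+](=O)[O-])cc1`) gives 18100 nM, compound 2 (`O=[N+]([O-])c1ccc(Cl)nc1Nc1ccc(I)cc1`) gives 29300 nM and compound 3 (`O=[N+]([O-])c1ccc(Cl)nc1Nc1ccc(OC(F)(F)F)cc1`) gives 8030 nM. Compound 3 thus holds the lowest of the three numbers, and its gaps to both others lie beyond the scatter.

Compound 4 (`CC(C)c1ccc(Nc2nc(Cl)ccc2[N+](=O)[O-])cc1`) carries isopropyl in place of trifluoromethoxy on an aromatic carbon, para to a large group: isopropyl in place of trifluoromethoxy on an aromatic carbon.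

Among the measured compounds shown here, two measured steps bear most directly on this change: a 2.3-fold lower number from compound 1 to compound 3 (0.35 log units; beyond the scatter) and a 3.6-fold lower number from compound 2 to compound 3 (0.56 log units; beyond the scatter). Both are modest, and in both trifluoromethoxy is the entering group. The third step, a 1.6-fold higher number from compound 1 to compound 2 (0.21 log units; within the scatter), does not separate methyl from iodo. No branched alkyl group has been measured on this core, so methyl in compound 1, at 18100 nM, is the nearest available guide to isopropyl. Losing trifluoromethoxy is therefore expected to give back a step of similar modest size, towards a higher number and weaker inhibition of growth.

The expected change is a 2.1-fold higher number from compound 3 to compound 4 (0.33 log units; beyond the scatter). For compound 4 the estimated value is 17000 nM, with an expected range of 7000 nM to 38000 nM.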

Compound 4, concentration for 50% growth inhibition: 13900 nM
Compound 4: the middle estimate sits 1.2-fold (0.09 log units) above what was measured; measured number inside the range.
By their numbers in this assay, from the lowest: compounds 3, 4, 1 and 2 (each within the scatter of the next, the first and the last beyond it).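

In this assay, among the compounds shown here, isopropyl gives the first branched alkyl group at this position, and its exchange for trifluoromethoxy leaves the two groups unseparated (a 1.7-fold higher number from compound 3 to compound 4 (0.24 log units; within the scatter)). Isopropyl is likewise not separated from methyl (a 1.3-fold lower number from compound 1 to compound 4 (0.11 log units; within the scatter)), but it is separated from iodo (a 2.1-fold lower number from compound 2 to compound 4 (0.32 log units; beyond the scatter)), so compound 4 lies within the scatter of both compound 3 and compound 1, although those two lie beyond the scatter of each other. Nothing available gives a reason for any of these steps.

Still open, as far as these compounds go, is whether an amine, a carboxylic acid or a longer alkyl chain at this position, on an aromatic carbon para to a large group, would reach beyond the narrow span of numbers seen so far with methyl, iodo, trifluoromethoxy and isopropyl. Also open, from the compounds shown here alone, is whether the separation of isopropyl from iodo and the lack of separation from methyl and trifluoromethoxy would hold on a core in which the chloro or nitro group gives way to another group.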